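The source may report more compounds than this note shows. Statements on the series, on what has been measured and on what is new or still open speak of the compounds shown alone.

Of the compounds shown here, three sharing one core have been tested in a functional assay on NIH3T3 cells (Mus musculus); on this read-out lower numbers stand for an effect already at smaller amounts and higher numbers for an effect only at larger amounts of compound. Compound 1, `CSCC[C@H](NC(=O)c1ccc(NCc2cncn2Cc2ccccc2C#N)cc1-c1ccccc1)C(=O)O`, gives only a limit of the assay, > 10 uM. Compound 2, `CSCC[C@H](NC(=O)c1ccc(NCc2cncn2Cc2ccc(C#N)cc2)cc1-c1ccccc1)C(=O)O`, likewise gives only a limit, > 10 uM. Compound 3, `CSCC[C@H](NC(=O)c1ccc(NCc2cncn2Cc2ccc([N+](=O)[O-])cc2)cc1-c1ccccc1)C(=O)O`, again gives only a limit, > 10 uM. Compound 2 therefore does not stand at a number but at a limit, and the two other values are limits too, as the limit of > 10 uM in this assay, at which 3 of the 3 values shown sit, states.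

Compound 4, `N#CCNC(=O)c1ccc(NCc2cncn2Cc2ccc(C#N)cc2)cc1-c1ccccc1`, differs from compound 2 in one place: cyanomethyl in place of 1-carboxy-3-(methylsulfanyl)propyl on an amide-type nitrogen. The measured steps bear on this only weakly. The step that the two limits leave unreadable from compound 1 to compound 2 and the step that the two limits leave unreadable from compound 1 to compound 3 and the step that the two limits leave unreadable from compound 2 to compound 3 all join two limits, so their size cannot be read, and none of them touches the amide-type nitrogen that the change in compound 4 concerns. Nothing in these three steps therefore tells how large the step that the limit leaves unreadable from compound 2 to compound 4 is expected to be, nor in which direction.

With only limits to go on, compound 4 is expected to sit near the same limit, so the estimate for compound 4 in this assay is 20 uM, with a range from 4 uM to 100 uM, and a numeric value is expected only with a modest chance.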

Compound 4, concentration for half-maximal effect: > 10 uM
Compound 4: no number, only a limit (the forecaster's own chance of this, stated with the estimate: 70%); the middle value is on the limit's open side.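

Among the compounds shown here, compound 2 and compound 4 both give only a limit in this assay, so no step between them can be read, and the same holds for every other pair here: the limit of > 10 uM in this assay, at which 4 of the 4 values shown sit. The compounds shown leave open how far the true value of each lies from that limit, and so whether any of these changes to the shared core alters the effect at all.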